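Swapping Fluoro for Methoxy in a Cytotoxicity Series

The source may hold more compounds than are shown below. What is called first, only, known or untested is meant among the compounds shown, and "the series" means these compounds.

Compound 1, `COc1ccc(/C=C/C(=N\O)c2ccc(Cl)cc2)cc1`, gives 24300 nM in an ADME assay on cells (Mus musculus, strain Balb/c) for cytotoxicity, read by MTT assay, with a stated time of 48 h; on this read-out lower numbers stand for higher toxicity in this test and higher numbers for lower toxicity in this test.
Compound 2, `O/N=C(\C=C\c1ccc(F)cc1)c1ccc(Br)cc1`, gives 20300 nM in this assay.

Compound 2 holds the lowest of the two numbers in this assay, but its nearest neighbour, compound 1, sits within the scatter, so the two cannot be told apart. Compound 3, `COc1ccc(/C=C/C(=N\O)c2ccc(Br)cc2)cc1`, is not yet measured. It differs from compound 2 in one place: methoxy in place of fluoro on an aromatic carbon. Because compound 1 gives 24300 nM while carrying that same methoxy group, no step beyond the scatter is expected in either direction. Compound 3 is therefore estimated at 22000 nM, between 10000 nM and 48000 nM. The expected step is a 1.1-fold higher number from compound 2 to compound 3 (0.03 log units; within the scatter).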

Compound 3, half-maximal cytotoxic concentration: 23700 nM
Beside the measured number, compound 3's estimate is 1.1-fold (0.03 log units) below it; low and high end bracket the measured number.
By their numbers in this assay, from the lowest: compounds 2, 3 and 1 (each within the scatter of the next).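

Methoxy in place of fluoro, on an aromatic carbon para to a large group, can now be read within a single pair: it gives a 1.2-fold higher number from compound 2 to compound 3 (0.07 log units; within the scatter) in this assay, so this swap does not separate the two compounds. Bromo in place of chloro on an aromatic carbon can also be read for the first time, and it gives a 1.0-fold lower number from compound 1 to compound 3 (0.01 log units; within the scatter), so this swap does not separate its pair either. Nothing measured here offers an explanation for these results.

Both changes keep to halogens and methoxy, so these pairs cannot show how an amine or a carboxylic acid at the same position would read. From the compounds shown here alone, a longer chain such as butoxy also remains open.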